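This account rests on a few compounds, and the source may have more. Where it says the series, first, only, none or still open, it means among the compounds named here.

In an ADME assay on the whole organism (Mus musculus, strain C57BL/6) for pharmacokinetics, read by HPLC, with a stated time of 6 h, at a dose of 25 mg/kg by the oral route (on this read-out higher numbers stand for higher exposure at the dose given and lower numbers for lower exposure), compound 1 (`O=C(O)[C@H](CO)NC(=O)[C@H]1C[C@H](O)CN1`) gives 4010 nM, compound 2 (`O=C(O)[C@@H](CO)NC(=O)[C@H]1C[C@@H](O)CN1`) gives 24000 nM and compound 3 (`O=C(O)[C@@H](CO)NC(=O)[C@H]1C[C@H](O)CN1`) gives 22900 nM. Compound 3 thus stands level with compound 2, within the scatter, and clear of compound 1. Compound 4 (`O=C(N[C@H](CO)C(=O)O)[C@@H]1C[C@H](O)CN1`) departs from compound 3 as follows: the two compounds have the same atoms and bonds and differ only in configuration as drawn: 1 of 3 stereo elements differ; a stereocentre at a saturated ring carbon is drawn R in compound 3 and S in compound 4. The chain stereocentre stays as drawn in compound 3.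

Inverting that chain stereocentre alone gave a 5.7-fold higher number from compound 1 to compound 3 (0.76 log units; beyond the scatter), beyond the scatter, and a 6.0-fold higher number from compound 1 to compound 2 (0.78 log units; beyond the scatter) is of similar size. Inverting a ring stereocentre gave a 1.0-fold lower number from compound 2 to compound 3 (0.02 log units; within the scatter), within the scatter. For the measured compounds named here, that centre is drawn S in compound 3, so the centre inverted here, drawn R in compound 3, is a different ring carbon with no measured step of its own. The flat ring step a 1.0-fold lower number from compound 2 to compound 3 (0.02 log units; within the scatter) is the nearest guide, so no change beyond the scatter is expected in this assay, though the range stays wide, with more room downward. The expected step is a 1.3-fold lower number from compound 3 to compound 4 (0.10 log units; within the scatter). The estimate for compound 4 is 18000 nM, within an expected range of 6000 nM to 40000 nM.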

Compound 4, maximal plasma concentration: 22200 nM
Estimate against measurement, compound 4: 1.2-fold (0.09 log units) below; the measured number falls inside the stated range.
By their numbers in this assay, from the lowest: compound 1; then compounds 4, 3 and 2 (each within the scatter of the next).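

For the compounds shown here, the ring carbon that had no measured step of its own also leaves the maximal plasma concentration flat in this assay: a 1.0-fold lower number from compound 3 to compound 4 (0.01 log units; within the scatter). Changing both ring stereocentres together does the same, a 1.1-fold lower number from compound 2 to compound 4 (0.03 log units; within the scatter), so compounds 2, 3 and 4, which share the chain stereocentre as drawn, show no dependence on ring configuration. Compound 1 alone stands apart, a 5.5-fold higher number from compound 1 to compound 4 (0.74 log units; beyond the scatter), and this step also carries a ring change, so the single-centre step from compound 1 to compound 3 remains the cleaner link to the chain stereocentre.

Only compound 1 carries the chain stereocentre drawn S, so whether ring configuration stays without effect in that chain series is open. Also open, as far as these compounds go, is whether this flatness would hold with a methyl ester in place of the carboxylic acid, or an amine in place of the ring hydroxyl.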